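This account rests on a few compounds, and the source may have more. Where it says the series, first, only, none or still open, it means among the compounds named here.

The compounds measured so far, each with its value in an assay on isolated protein for inhibition of protein deacetylase HDAC6 (Homo sapiens), read by fluorescence; a higher number here means a weaker inhibitor, a lower number a stronger inhibitor:

compound 1, `C#CCN(C)CCCOc1cc(NCc2ccc(/C=C/C(=O)NO)cc2)ccc1Cl`: 100 nM
compound 2, `C#CCN(C)CCCOc1cc(NC(=O)CCCCCCCC(=O)NO)ccc1Cl`: 80 nM
compound 3, `C#CCN(C)CCCOc1ccc(NC(=O)CCCCCCC(=O)NO)cc1Cl`: 6 nM

Compound 2 has the second highest of these three numbers. Its nearest neighbour is compound 1, whose value sits within the scatter of that of compound 2, so no order can be read between them. Compound 3 is far off, with a clearly lower number that lies beyond the scatter.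

Compound 4, `C#CCN(C)CCCOc1cc(NC(=O)CCCCCCC(=O)NO)ccc1Cl`, differs from compound 2 in one place: hydroxycarbamoyl in place of (hydroxycarbamoyl)methyl on a saturated chain carbon, six bonds along the chain from a carbonyl carbon. Compound 3 has the same shorter chain but another ring attachment, so it gives only a hint. A step of modest size towards a lower number is expected, a 2.7-fold lower number from compound 2 to compound 4 (0.43 log units; beyond the scatter), in part because compound 3 shows 6 nM. For compound 4 the estimate is 30 nM, with a range from 8 nM to 100 nM.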

Compound 4, half-maximal inhibitory concentration: 10 nM
Compound 4: the middle estimate sits 3.0-fold (0.48 log units) above what was measured; low and high end bracket the measured number.
By their numbers in this assay, from the lowest: compounds 3 and 4 (each within the scatter of the next); then compounds 2 and 1 (each within the scatter of the next).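

In this assay, hydroxycarbamoyl in place of (hydroxycarbamoyl)methyl gives an 8.0-fold lower number from compound 2 to compound 4 (0.90 log units; beyond the scatter). For the compounds shown here, this is the first pair here that differs in one place, so it shows that chain length alone can move this number, with the ring attachment held the same. Nothing given here accounts for the step.

From the compounds shown here alone, it remains open whether 2-(hydroxycarbamoyl)ethyl, which lies on the same series of chains, or a still shorter chain would continue this trend. Going by these compounds, it is also open how a carboxylic acid in place of hydroxycarbamoyl would read at this position.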